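Aromatising the five-membered ring: compound 2 to compound 3

This account rests on a few compounds, and the source may have more. Where it says the series, first, only, none or still open, it means among the compounds named here.

Compound 1 `O=c1ccc2cc(N3CC=CC3)ccc2o1`: 90%
Compound 2 `Cc1cc(=O)oc2cc(N3CC=CC3)ccc12`: 85%

Of the compounds shown here, two have been measured in a functional assay, with a stated time of 30 min, tested at 100 uM; a lower number here means less inhibition, a higher number more inhibition at the concentration tested (going by the name of the read-out). Compound 1 gives 90%, and compound 2 gives 85%; these two numbers lie within the usual scatter of each other, so compound 2 is not separated from compound 1 on this read-out. Compound 3 `Cc1cc(=O)oc2cc(-n3cccc3)ccc12` differs from compound 2 by a group of 5 heavy atoms (4 carbon, 1 nitrogen; one five-membered aromatic ring with 1 hetero atom) in place of a group of 5 heavy atoms (4 carbon, 1 nitrogen; one five-membered non-aromatic ring with 1 hetero atom), on an aromatic carbon. For the measured compounds named here, no step between measured compounds exists to size such a change, so the expectation rests on the two high numbers alone. Compound 3 is expected to give 80%, with a range from 55% to 95%. The estimated step of a number 5 percentage points lower from compound 2 to compound 3 (within the scatter) is expected to stay within the scatter.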

Compound 3, a percentage reported as inhibition, at one concentration (the size of the read-out at that concentration, not a potency): 9%
Beside the measured number, compound 3's estimate is 71 percentage points above it; measured number below the stated range.
By their numbers in this assay, from the lowest: compound 3; then compounds 2 and 1 (each within the scatter of the next).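

Replacing the non-aromatic ring with 1H-pyrrol-1-yl on this aromatic carbon gives a number 76 percentage points lower from compound 2 to compound 3 (beyond the scatter) in this assay and so shows that the read-out depends strongly on which five-membered ring sits here. Compound 1 and compound 2 carry the same non-aromatic ring and could not show this. No measurement available here accounts for the size of this step.

The compounds shown leave open whether the saturated pyrrolidine ring or an open-chain amine such as dimethylamino at this position would keep the high inhibition of compound 2.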